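Taking the Nitrogen Substituent Off Compound 2

A few compounds are considered here, and "the series" means these few. Any claim that something is new, unique, unknown or untested is made for them only; others in the source may bear on it.

Two compounds in this set share one core. Compound 1 `CC(C)N1C(=O)NC2(CC2c2ccc3cccc(OCc4ccccc4)c3n2)C1=O` carries an isopropyl group on an amide-type nitrogen in a ring, and in a functional assay on the whole organism (strain Kunming) with Mus musculus as the target, with a stated time of 0.5 h (a higher number here means that more compound is needed for the effect, a lower number that less compound is needed), compound 1 gives 100 mg/kg. Compound 2 `O=C1NC2(CC2c2ccc3cccc(OCc4ccccc4)c3n2)C(=O)N1c1cc(Cl)cc(Cl)c1` bears a 3,5-dichlorophenyl group at that nitrogen, and in this assay compound 2 gives 300 mg/kg. The step between them is a 3.0-fold higher number from compound 1 to compound 2 (0.48 log units; beyond the scatter). Compound 2 therefore stands at the higher of the two numbers. Compound 3 `O=C1NC(=O)C2(CC2c2ccc3cccc(OCc4ccccc4)c3n2)N1` differs from compound 2 by hydrogen in place of 3,5-dichlorophenyl on an amide-type nitrogen in a ring. For the measured compounds named here, only that one measured step bears on the change: swapping the isopropyl for the dichlorophenyl raised the dose needed, so the larger group sat at the higher number. Going by the values given here, removing the group altogether is a different kind of change, and no measured pair shows its effect directly. The expected step is a 2.0-fold lower number from compound 2 to compound 3 (0.30 log units; within the scatter). Compound 3 is therefore estimated to give 150 mg/kg in this assay, with a likely range from 50 mg/kg to 450 mg/kg.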

Compound 3, minimum effective dose: 300 mg/kg
The estimate for compound 3 lay 2.0-fold (0.30 log units) below the measured number; the measured number falls inside the stated range.
By their numbers in this assay, from the lowest: compound 1; then compounds 2 and 3 (each within the scatter of the next).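

In this assay the step reads no change at the digits printed from compound 2 to compound 3 (within the scatter), so the 3,5-dichlorophenyl group can leave this ring nitrogen entirely without the number moving. Set beside a 3.0-fold higher number from compound 1 to compound 3 (0.48 log units; beyond the scatter), this undoes the simple reading that a bigger group here needs more compound: the hydrogen of compound 3 and the 3,5-dichlorophenyl of compound 2 give the same number, and only the isopropyl of compound 1 stands lower. No measurement here offers an explanation for this pattern.

As far as these compounds go, it remains open whether the lower number belongs to isopropyl alone or would also appear with a methyl, a cyclopropyl or a longer chain such as n-butyl on this nitrogen. A plain phenyl without chlorine, or a chain ending in an amine, could also show whether other groups here move the number at all.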